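A few compounds are considered here, and "the series" means these few. Any claim that something is new, unique, unknown or untested is made for them only; others in the source may bear on it.

Working notes on the series. For the measured compounds named here, compound 1 `Nc1cc(N)c2nc(-c3ccccc3)c(Oc3ccc(Cl)c(Cl)c3)nc2c1` is the only member with a number in a functional assay on SK-MEL-5 cells (Homo sapiens) for inhibition, read by sulforhodamine B assay, with a stated time of 48 h; a lower number here means that less compound is tolerated, a higher number that more compound is tolerated: compound 1 gives 83200 nM. Compound 2 `CCOC(=O)[C@H](CCC(=O)O)NC(=O)c1ccc(CNc2nc3cc(N)cc(N)c3nc2-c2ccccc2)cc1` gives in this assay only a limit, < 100000 nM, which is the limit of < 100000 nM in this assay, at which 1 of the 2 values shown sits. Going by the values given here, no pair of measured compounds differs in a single place, so no measured step is available to set the scale for the change that follows.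

Compound 3 `Nc1cc(N)c2nc(-c3ccccc3)c(Sc3ccc(F)cc3)nc2c1` is not yet measured. It differs from compound 1 by (4-fluorophenyl)sulfanyl in place of 3,4-dichlorophenoxy on an aromatic carbon. Among the compounds with values here, nothing among the measured compounds shows how this assay responds to an exchange of this kind. The step expected in this assay is none beyond the scatter, in either direction. On that basis compound 3 is expected to give 80000 nM, with the estimate spanning 25000 nM to 150000 nM. The step from compound 1 to compound 3 that this estimate means is a 1.0-fold lower number from compound 1 to compound 3 (0.02 log units; within the scatter), and it is expected to stay within the usual scatter. The measurement of compound 3 is awaited.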

Compound 3, concentration lethal to 50% of the cells: 70800 nM
Estimate against measurement, compound 3: 1.1-fold (0.05 log units) above; measured number inside the range.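

For the compounds shown here, the first measured step is a 1.2-fold lower number from compound 1 to compound 3 (0.07 log units; within the scatter), read in this assay, for (4-fluorophenyl)sulfanyl in place of 3,4-dichlorophenoxy on the aromatic carbon next to the ring nitrogen. This exchange alters the linking atom and the halogens on the ring at once, and together they leave the number unchanged within the scatter, so at this position the two aryl groups cannot be told apart and the step cannot be assigned to either alteration. How much this single step can show is restricted, because the measured numbers in this series stand not far from the top of what the assay reports: the limit of < 100000 nM in this assay, at which 1 of the 3 values shown sits.

A 4-fluorophenoxy group at the same carbon would separate the sulfur-for-oxygen exchange from the change in halogens, and the compounds shown do not settle whether the two alterations each do nothing or offset each other. Also open, as far as these compounds go, is whether a group of a different kind on this carbon, such as dimethylamino, would move the number beyond the scatter at all.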